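Removing a Trifluoromethyl from an Inactive Amide

The source may report more compounds than this note shows. Statements on the series, on what has been measured and on what is new or still open speak of the compounds shown alone.

Compound 1 `Cc1ccc(C(=O)Nc2nc(Cl)c3cn(C)nc3n2)cc1` and compound 2 `CC(C)(C)Cn1cc2c(Cl)nc(NC(=O)c3ccc(C(F)(F)F)cc3)nc2n1` share one core and were both tested in an assay on CHO cells for displacement of a labelled ligand from adenosine receptor A1 (Homo sapiens), read by scintillation counting, with a stated time of 3 h; a lower number here means a stronger inhibitor, a higher number a weaker inhibitor. For compound 1 the assay returned only a limit, > 100000 nM. For compound 2 it likewise returned only a limit, > 100000 nM. Every value shown therefore rests at the same place, (the limit of > 100000 nM in this assay, at which 2 of the 2 values shown sit). Compound 3 `CC(C)(C)Cn1cc2c(Cl)nc(NC(=O)c3ccccc3)nc2n1` differs from compound 2 by hydrogen in place of trifluoromethyl on an aromatic carbon. For the measured compounds named here, with no measured step available, the change is expected to be none beyond the scatter, a number no higher from compound 2 to compound 3 (the limit leaves the size open). Compound 3 is accordingly estimated at 100000 nM, within a range from 30000 nM to 300000 nM.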

Compound 3, inhibition constant: 11000 nM
Estimate against measurement, compound 3: 9.1-fold (0.96 log units) above; measured number outside the range, below it.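

With hydrogen in place of trifluoromethyl, para to a large group, this assay gives an at least 9.0-fold lower number from compound 2 to compound 3 (0.95 log units; beyond the scatter). For the compounds shown here, this shows that the group at this place on the aromatic ring can shift the reading, which the earlier compounds could not show. Compound 2 stands only at a limit, so the step has a lower bound but no known full size: the limit of > 100000 nM in this assay, at which 2 of the 3 values shown sit. The compounds shown leave open how a methoxy group, a fluorine atom or an amine at this place would read, and whether any would give a lower number than compound 3.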